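The source may hold more compounds than are shown below. What is called first, only, known or untested is meant among the compounds shown, and "the series" means these compounds.

Working notes on the amide series. All three measured compounds share one core and differ only in the aryl group on the carbonyl carbon. Compound 1 `O=C(Nc1cccc(-c2oc3cc(-c4ccc(F)cc4)ccc3c(=O)c2O)c1)c1ccc(F)cc1` gives 14200 nM in a functional assay on HCC1937 cells (Homo sapiens) for antiproliferative activity, read by CCK-8 assay, with a stated time of 72 h; a higher number here means a weaker inhibitor, a lower number a stronger inhibitor. Compound 2 `COc1ccccc1C(=O)Nc1cccc(-c2oc3cc(-c4ccc(F)cc4)ccc3c(=O)c2O)c1` gives 9050 nM in this assay, and compound 3 `O=C(Nc1cccc(-c2oc3cc(-c4ccc(F)cc4)ccc3c(=O)c2O)c1)c1cccc(F)c1` gives 6590 nM in this assay. Of the three numbers, that of compound 3 is the lowest, but only a 2.2-fold lower number from compound 1 to compound 3 (0.33 log units; beyond the scatter) is beyond the scatter; a 1.4-fold lower number from compound 2 to compound 3 (0.14 log units; within the scatter) is within it, as is a 1.6-fold lower number from compound 1 to compound 2 (0.20 log units; within the scatter). Exchanging the aryl on the carbonyl carbon has therefore shifted the numbers only modestly so far.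

Compound 4 `O=C(Nc1cccc(-c2oc3cc(-c4ccc(F)cc4)ccc3c(=O)c2O)c1)c1ccc([N+](=O)[O-])cc1` is the next step from compound 3: 4-nitrophenyl in place of 3-fluorophenyl on a carbonyl carbon. The three measured steps all bear on this, since each swaps the same aryl group on the carbonyl carbon, and none exceeds a modest size; the largest is a 2.2-fold lower number from compound 1 to compound 3 (0.33 log units; beyond the scatter). A step of similar size is expected here, with the direction uncertain, since a return toward the numbers of compound 1 and compound 2 is as plausible as a further fall. For compound 4 the expected step is a 1.2-fold higher number from compound 3 to compound 4 (0.08 log units; within the scatter). Compound 4 is expected to give 8000 nM in this assay, within a range from 3500 nM to 18000 nM.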

Compound 4, half-maximal inhibitory concentration: 5640 nM
For compound 4 the middle estimate is 1.4-fold (0.15 log units) above the measured one; measured number inside the range.
By their numbers in this assay, from the lowest: compounds 4, 3, 2 and 1 (each within the scatter of the next, the first and the last beyond it).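

Working notes, continued. Putting a nitro group on this aryl ring leaves the number in the same range in this assay, with a 1.2-fold lower number from compound 3 to compound 4 (0.07 log units; within the scatter) and a 1.6-fold lower number from compound 2 to compound 4 (0.21 log units; within the scatter) both within the scatter, so compound 4 cannot be separated from compound 2 or compound 3. Only a 2.5-fold lower number from compound 1 to compound 4 (0.40 log units; beyond the scatter) goes beyond the scatter, and since that step is nitro in place of fluoro on an aromatic carbon, exchanging this one substituent on the aryl ring is enough to set compound 4 apart from compound 1, though only modestly and with compound 2 still inseparable from both. No measurement available here explains these steps.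

The compounds shown keep a substituted phenyl group on the carbonyl carbon, so it remains open whether a ring bearing an amine or a carboxylic acid, or a saturated alkyl chain in place of the phenyl, would move the number further. Also open, as far as these compounds go, is whether the nitro group gives the same step when it sits on the ring in the position held by the fluoro of 3-fluorophenyl.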